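Shortening the Side Chain from Compound 3 to Compound 4

This account rests on a few compounds, and the source may have more. Where it says the series, first, only, none or still open, it means among the compounds named here.

In a functional assay on Raji cells (Homo sapiens) (on this read-out higher numbers stand for weaker inhibition and lower numbers for stronger inhibition), three compounds have been measured:

compound 1, `CCCCCCCCc1cn([C@H]2C[C@H](O)[C@@H](CO)O2)c(=O)[nH]c1=O`: 52 ug/mL
compound 2, `CCCCCCc1cn([C@H]2C[C@H](O)[C@@H](CO)O2)c(=O)[nH]c1=O`: 151 ug/mL
compound 3, `CCCCCCc1cn([C@H]2C[C@@H]3OP(=O)(O)OC[C@H]3O2)c(=O)[nH]c1=O`: > 500 ug/mL

Compound 3 stands apart from the first two: its result is a limit of the assay and not a number, as the limit of > 500 ug/mL in this assay, at which 1 of the 3 values shown sits, records. Compound 4, `CCCCCc1cn([C@H]2C[C@@H]3OP(=O)(O)OC[C@H]3O2)c(=O)[nH]c1=O`, differs from compound 3 by hydrogen in place of methyl on a saturated chain carbon, five bonds along the chain from an aromatic carbon. Among the measured compounds shown here, the one measured step of the same kind, a 2.9-fold higher number from compound 1 to compound 2 (0.46 log units; beyond the scatter), shortens the chain on the core of compound 1 and gives a modest rise in the number. A further shortening is therefore expected to raise the number or leave it, and since compound 3 already sits at the limit, compound 4 is expected to sit there too. Compound 4 is estimated at 900 ug/mL with a range from 400 ug/mL to 2500 ug/mL, which means an expected step that the limit leaves unreadable from compound 3 to compound 4.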

Compound 4, concentration for 50% inhibition: > 500 ug/mL
Compound 4 was reported as a limit (the forecaster's own chance of this, stated with the estimate: 85%); the middle value lies beyond the limit too.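

Among the compounds shown here, compound 3 and compound 4 are both reported only as limits, so no step between them can be read: the limit of > 500 ug/mL in this assay, at which 2 of the 4 values shown sit. The compounds shown leave open whether shortening the chain changes inhibition at all on the core of compound 3.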